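Working notes: from compound 2 to compound 3

A few compounds are considered here, and "the series" means these few. Any claim that something is new, unique, unknown or untested is made for them only; others in the source may bear on it.

Measured in a functional assay on HeLa S3 cells (Homo sapiens) for cytotoxicity, read by microscopy, with a stated time of 48 h; on this read-out higher numbers stand for weaker inhibition and lower numbers for stronger inhibition:
- compound 1 `C=C(CO)C(=O)O[C@H]1C/C(C)=C/CC/C(CO)=C/[C@H]2OC(=O)[C@@H](CN3C[C@@H](CO)[C@]4(O)O[C@H]5C/C(C)=C/CC/C(CO)=C/[C@H]6OC(=O)[C@]4(C3)[C@H]56)[C@H]12`: > 10000 nM
- compound 2 `C=C(CO)C(=O)O[C@H]1C/C(C)=C/CC/C(CO)=C/[C@H]2OC(=O)[C@@H](CN[C@@H](C(=O)O)C(C)C)[C@H]12`: > 10000 nM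

Compound 2 gives > 10000 nM, which is a limit of the assay and not a number. Compound 1 gives > 10000 nM, which is also a limit. Among the compounds with values here, the series so far therefore offers no numeric value, only (the limit of > 10000 nM in this assay, at which 2 of the 2 values shown sit).

Compound 3 `C=C(CO)C(=O)O[C@H]1C/C(C)=C/CC/C(CO)=C/[C@H]2OC(=O)[C@@H](CN[C@H](CC(C)C)C(=O)O)[C@H]12` differs from compound 2 by one change isobutyl in place of isopropyl on a saturated chain carbon bound to an amine nitrogen and a carbonyl carbon. Within the data shown here, no step between measured compounds is available to size this change directly.

In this assay, no shift beyond the usual scatter is expected, and no firm direction, with compound 2 as the only close reference at > 10000 nM. The expected change is small, a step that the limit leaves unreadable from compound 2 to compound 3. A further limit rather than a number is the likeliest report for compound 3. Compound 3 is estimated at 14000 nM, with an expected range from 6000 nM to 30000 nM.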

Compound 3, half-maximal inhibitory concentration: > 10000 nM
Compound 3: only a limit was reported (the forecaster's own chance of this, stated with the estimate: 80%); the middle value lies beyond the limit too.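

In this assay, compound 2 and compound 3 are both reported only as limits and not as numbers, so no step can be read for isobutyl in place of isopropyl. The compounds shown leave open whether this change has any effect on the read-out in this assay, with the series resting so far on one reading: the limit of > 10000 nM in this assay, at which 3 of the 3 values shown sit.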